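The source may hold more compounds than are shown below. What is called first, only, known or untested is meant among the compounds shown, and "the series" means these compounds.

In an ADME assay on microsomes from liver (Homo sapiens) for metabolic stability, with a stated time of 10 min (on this read-out lower numbers stand for a less stable compound and higher numbers for a more stable compound), compound 1 `CC(=O)N1CC[C@H](C(=O)N2CC[C@](c3ccc(C(OCc4c(F)cccc4F)(C(F)(F)F)C(F)(F)F)cc3)(S(=O)(=O)c3ccc(F)cc3)C2)C1` gives 19% and compound 2 `CC(=O)N1CCC(C)(C(=O)N2CC[C@](c3ccc(C(OCc4c(F)cccc4F)(C(F)(F)F)C(F)(F)F)cc3)(S(=O)(=O)c3ccc(F)cc3)C2)CC1` gives 1%, the lower of the two numbers. Compound 3 `CC(=O)N1CCC(O)(C(=O)N2CC[C@](c3ccc(C(OCc4c(F)cccc4F)(C(F)(F)F)C(F)(F)F)cc3)(S(=O)(=O)c3ccc(F)cc3)C2)CC1` differs from compound 2 by hydroxy in place of methyl on a saturated ring carbon. For the measured compounds named here, the only measured step, a number 18 percentage points lower from compound 1 to compound 2 (beyond the scatter), is modest and reflects a different change, so it offers only a rough guide to size. Compound 2 has almost no room to fall at 1%, so a rise of similar size is expected. The expected change is a number 13 percentage points higher from compound 2 to compound 3 (beyond the scatter). Compound 3 is estimated at 14%, with a range of 2% to 35%.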

Compound 3, percent of the compound remaining: 16%
The estimate for compound 3 lay 2 percentage points below the measured number, and the stated range covers the measured number.
By their numbers in this assay, from the lowest: compound 2; then compounds 3 and 1 (each within the scatter of the next).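

In this assay, hydroxy in place of methyl on this saturated ring carbon gives a number 15 percentage points higher from compound 2 to compound 3 (beyond the scatter), showing that the number depends on the group held at this position and not on the six-membered ring alone. With 1-acetyl-4-hydroxypiperidin-4-yl in place of 1-acetylpyrrolidin-3-yl, the change is a number 3 percentage points lower from compound 1 to compound 3 (within the scatter), so these two groups cannot be told apart here. No available evidence accounts for the effect of exchanging methyl for hydroxy. Going by these compounds, whether an amine, a methoxy group or a fluorine on the same ring carbon would track hydroxy or methyl remains open.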